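The source may report more compounds than this note shows. Statements on the series, on what has been measured and on what is new or still open speak of the compounds shown alone.

Three compounds share one core and differ only in the aryl group on it. Compound 1 `Fc1ccc(-c2cn3ccnc3c(-c3ccc4ncn(C5CCCCC5)c4c3)n2)cc1` gives 2.01 in a physicochemical assay for lipophilicity, using the shake flask method, in phosphate buffer, measured as octanol-water partition, with a stated time of 85 min, at pH 7.4; a lower number here means a more polar compound, a higher number a more lipophilic compound. Compound 2 `CC(=O)c1ccc(-c2cn3ccnc3c(-c3ccc4ncn(C5CCCCC5)c4c3)n2)cc1` gives 2.06 in this assay, and compound 3 `Clc1ccc(-c2cn3ccnc3c(-c3ccc4ncn(C5CCCCC5)c4c3)n2)cc1` gives 1.51, the lowest of the three numbers. Among the measured compounds shown here, the steps so far are a number 0.05 log units higher from compound 1 to compound 2 (within the scatter), a number 0.50 log units lower from compound 1 to compound 3 (beyond the scatter) and a number 0.55 log units lower from compound 2 to compound 3 (beyond the scatter); each swaps one substituent on the phenyl ring and leaves the ring itself in place.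

Compound 4 `c1csc(-c2cn3ccnc3c(-c3ccc4ncn(C5CCCCC5)c4c3)n2)c1` is made from compound 3 by thiophen-2-yl in place of 4-chlorophenyl on an aromatic carbon. For the measured compounds named here, no measured step exchanges the whole aromatic ring, so none bears directly on this change; the substituent swaps only show that this position moves the number by about half a unit at most. Since the chlorine leaves and a smaller ring enters, a modest drop is expected, a number 0.26 log units lower from compound 3 to compound 4 (within the scatter). Compound 4 is therefore estimated at 1.25 in this assay, within a range from 0.75 to 1.85.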

Compound 4, partition coefficient: 1.38
The estimate for compound 4 lay 0.13 log units below the measured number, and the stated range covers the measured number.
By their numbers in this assay, from the lowest: compounds 4 and 3 (each within the scatter of the next); then compounds 1 and 2 (each within the scatter of the next).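

Compound 4 shows that the whole aromatic ring at this position can be exchanged, not only a substituent on it: in this assay thiophen-2-yl in place of 4-chlorophenyl gives a number 0.13 log units lower from compound 3 to compound 4 (within the scatter) and so leaves the number where the chlorinated compound had it. The same ring exchange set against the other two aryl groups gives a number 0.68 log units lower from compound 2 to compound 4 (beyond the scatter) and a number 0.63 log units lower from compound 1 to compound 4 (beyond the scatter), which places compound 4 with compound 3 in a lower pair, apart from compound 1 and compound 2. Nothing shown here explains any of these steps.

The compounds shown leave open how an amine or a carboxylic acid on the phenyl ring would move the number. They also leave open what a longer chain in place of the aromatic ring at this position would do.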